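The source may report more compounds than this note shows. Statements on the series, on what has been measured and on what is new or still open speak of the compounds shown alone.

In an ADME assay on Vero cells (Chlorocebus sabaeus) for cytotoxicity, read by MTT assay, with a stated time of 72 h (on this read-out higher numbers stand for weaker inhibition and lower numbers for stronger inhibition), the measured compounds give these values:

compound 1 `O=C(NNC(=O)c1cc([N+](=O)[O-])c[nH]1)Nc1ccc([N+](=O)[O-])cc1` gives 211000 nM
compound 2 `Cn1cc([N+](=O)[O-])cc1C(=O)NNC(=O)Nc1ccc([N+](=O)[O-])cc1` gives 402000 nM
compound 3 `Cc1ccccc1NC(=S)NNC(=O)c1cc([N+](=O)[O-])cn1C` gives 471000 nM

Compound 2 at 402000 nM lies within the usual scatter of both other compounds, so its place among the three numbers is not firm. Compound 4 `Cn1cc([N+](=O)[O-])cc1C(=O)NNC(=O)Nc1ccc(Cl)cc1` has not yet been measured in this assay and is the next case. Going by the values given here, it carries chloro in place of nitro on an aromatic carbon, para to a large group, a swap counted as chloro in place of nitro on an aromatic carbon and the only difference from compound 2.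

Among the compounds with values here, the one measured step between close relatives is a 1.9-fold higher number from compound 1 to compound 2 (0.28 log units; within the scatter) and it comes from methyl in place of hydrogen on an aromatic nitrogen, so it bears on this swap only weakly. Carrying no nitro on its six-membered ring and differing from compound 2 in other places as well, compound 3 gives 471000 nM in the same range of numbers. Within the data shown here, no measured step replaces nitro with chloro, so the expectation is loose: no step beyond the scatter, in either direction. The expected change is a 1.3-fold lower number from compound 2 to compound 4 (0.13 log units; within the scatter) as a rough estimate. For compound 4 the estimated value is 300000 nM with an expected range from 120000 nM to 700000 nM as a deliberately wide span.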

Compound 4, half-maximal inhibitory concentration: 290000 nM
For compound 4 the middle estimate is 1.0-fold (0.01 log units) above the measured one, and the stated range covers the measured number.
By their numbers in this assay, from the lowest: compounds 1, 4, 2 and 3 (each within the scatter of the next, the first and the last beyond it).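

Moving from nitro to chloro at this place on the six-membered aromatic ring of carbon only, para to a large group, gives a 1.4-fold lower number from compound 2 to compound 4 (0.14 log units; within the scatter) in this assay, so the two numbers cannot be told apart. The earlier close pair tested only methyl in place of hydrogen on an aromatic nitrogen, whereas this pair shows that the other end of the molecule can also be altered without a step beyond the scatter, even though the swap takes out three heavy atoms and two hydrogen-bond acceptors and puts in one heavy atom and no acceptor. No supporting measurement is available to explain why the number stays within the scatter across this swap.

Open, going by these compounds, is whether an amine, a carboxylic acid or a longer chain at this same place would also stay within the scatter of compound 2, or would give a clear step in either direction. One swap at one place also cannot show whether chloro would behave the same way on the core of compound 1, which has hydrogen rather than methyl on its aromatic nitrogen.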